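The source may hold more compounds than are shown below. What is called first, only, known or untested is meant among the compounds shown, and "the series" means these compounds.

In a functional assay on HL-60 cells (Homo sapiens) for inhibition, read by CCK-8 assay, with a stated time of 48 h (on this read-out lower numbers stand for stronger inhibition and higher numbers for weaker inhibition), compound 1 `O=S(=O)(NCCNC(=S)Nc1cccc(Cl)c1)c1ccc(-c2ccccc2OCc2cccc(O)c2)s1` gives 1800 nM, and compound 3 `O=C(NCCNS(=O)(=O)c1ccc(-c2ccccc2O[C@H]2CC[C@@H](O)CC2)s1)Nc1cc(C(F)(F)F)cc(C(F)(F)F)c1` gives 3100 nM. Compound 2 `O=S(=O)(NCCNC(=S)Nc1cccc(Cl)c1)c1ccc(-c2ccccc2OCc2ccccc2)s1` has no exact number, only a limit of the assay, > 50000 nM. Its standing rests on (the limit of > 50000 nM in this assay, at which 1 of the 3 values shown sits). Compound 4 `O=S(=O)(NCCNC(=S)Nc1ccc(Cl)cc1)c1ccc(-c2ccccc2OCc2ccccc2)s1` departs from compound 2 by 4-chlorophenyl in place of 3-chlorophenyl on an amide-type nitrogen. Among the measured compounds shown here, no measured step touches that place. For the measured compounds named here, the one step available, an at least 27-fold higher number from compound 1 to compound 2 (1.44 log units; beyond the scatter), is large and beyond the scatter, but it concerns hydrogen in place of hydroxy on an aromatic carbon. It bears only indirectly: compound 4 lacks that hydroxy just as compound 2 does, and that loss accompanies an at least 27-fold higher number from compound 1 to compound 2 (1.44 log units; beyond the scatter). No step beyond the scatter is therefore expected in this assay, and the assay may again report only a limit. The estimated change is a number no higher from compound 2 to compound 4 (the limit leaves the size open). Compound 4 is expected near 50000 nM, with an estimated range of 15000 nM to 100000 nM.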

Compound 4, half-maximal inhibitory concentration: > 50000 nM
Compound 4 was reported as a limit; the forecaster's own chance of this, stated with the estimate: 70%; the middle value sits exactly at the limit.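

Compound 2 and compound 4 both stand only as limits in this assay, and no step can be read between them. The compounds shown leave open whether 4-chlorophenyl in place of 3-chlorophenyl changes inhibition at all, including in a compound that keeps the hydroxy of compound 1.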